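This account rests on a few compounds, and the source may have more. Where it says the series, first, only, none or still open, it means among the compounds named here.

In a functional assay on A-431 cells (Homo sapiens) for cytotoxicity, read by MTT assay, with a stated time of 72 h, tested at 3 uM (on this read-out higher numbers stand for more inhibition of growth at the one concentration tested and lower numbers for less inhibition of growth), compound 1, whose structure is `Cc1ccnc(/C(N)=N/NC(=S)N2CCCC2)c1`, gives 63%, the highest of the three numbers recorded. Compound 3 `N/C(=N\NC(=S)N1CCN(c2ccccn2)CC1)c1ccc(F)cn1` gives 43% in this assay, a number that lies beyond the scatter below compound 1, and compound 2 `Cc1cccc(/C(N)=N/NC(=S)N2CCCCC2)n1` gives 36.6% in this assay, the furthest from compound 1 and also beyond the scatter. No single-point change between these measured compounds has been worked out, so the account turns to the unmeasured compound 4 `Cc1ccnc(/C(N)=N/NC(=S)N2CCOCC2)c1`, which differs from compound 1 in one place: morpholin-4-yl in place of pyrrolidin-1-yl on a thiocarbonyl carbon. The two weaker neighbours, compound 3 and compound 2, both carry six-membered rings on the thiocarbonyl carbon, but they also differ elsewhere, so no firm direction follows from them. A modest fall in this assay is expected from compound 1 to compound 4, of the size a number 13 percentage points lower from compound 1 to compound 4 (beyond the scatter). Compound 4 is therefore estimated at 50% in this assay, within a range from 30% to 70%.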

Compound 4, percent growth inhibition at one concentration: 35.5%
Beside the measured number, compound 4's estimate is 14.5 percentage points above it; low and high end bracket the measured number.
By their numbers in this assay, from the lowest: compounds 4, 2 and 3 (each within the scatter of the next); then compound 1.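

Among the compounds shown here, with the core held constant, morpholin-4-yl in place of pyrrolidin-1-yl on the thiocarbonyl carbon gives a number 27.5 percentage points lower from compound 1 to compound 4 (beyond the scatter) in this assay, the first reading of a change at this place alone. The earlier compounds shown here differed in more than one place, whereas this step ties the loss of growth inhibition to the group on the thiocarbonyl carbon, although ring size and the added ring oxygen change together in it. No measurement shown here accounts for the fall.

A piperidin-1-yl group on the core of compound 1 would help to separate the part played by the larger ring from that of the ring oxygen. As far as these compounds go, whether an open-chain dimethylamino group would keep the growth inhibition of compound 1, and whether the step holds on other cores, remains open.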